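Extending the methyl on a Toll-like receptor 8 agonist core

A few compounds are considered here, and "the series" means these few. Any claim that something is new, unique, unknown or untested is made for them only; others in the source may bear on it.

Measured compounds:
- compound 1, `CCCCNc1nc(N)nc2cc(C(=O)N(C)C)ccc12`, 0.5 uM
- compound 2, `CCCCNc1nc(N)nc2cccc(C)c12`, 0.3 uM

Both compounds were tested in an ADME assay on HEK293 cells for agonist activity at Toll-like receptor 8 (Homo sapiens), read by a luciferase reporter, with a stated time of 6 h; on this read-out lower numbers stand for an effect already at smaller amounts and higher numbers for an effect only at larger amounts of compound. Compound 1 gives 0.5 uM, and compound 2 gives 0.3 uM. Of the two numbers compound 2 has the lower one, but the gap to compound 1 lies within the scatter of this kind of measurement, so the two compounds cannot be ranked against each other on these data.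

Compound 3, `CCCCNc1nc(N)nc2cccc(CC3CCCC3)c12`, has not yet been measured. Its structure differs from that of compound 2 in one place: cyclopentyl in place of hydrogen on a saturated chain carbon bound to an aromatic carbon. Read one bond further out, the methyl of compound 2 becomes a cyclopentylmethyl in compound 3.

For the measured compounds named here, no step between two measured compounds describes such a change, so there is nothing in the data that shows what it does. The expectation for compound 3 rests on compound 2 alone and is a modest move towards a lower number, of about a 2.0-fold lower number from compound 2 to compound 3 (0.30 log units; within the scatter), which may not exceed the scatter. Compound 3 is therefore estimated at 0.15 uM, with a range from 0.04 uM to 0.6 uM.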

Compound 3, minimum effective concentration: > 25 uM
Compound 3: no number, only a limit; the forecaster's own chance of this, stated with the estimate: 5%; middle value at least 160-fold (2.22 log units) away from the limit.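

This position on the shared core is not open to any extension: in this assay, cyclopentyl in place of hydrogen on a saturated chain carbon bound to an aromatic carbon gives an at least 83-fold higher number from compound 2 to compound 3 (1.92 log units; beyond the scatter). That is a change well beyond the usual scatter, and a single change of one group is enough to produce it. Nothing of the kind could be seen from compound 1 and compound 2, which differ in more than one place and whose values lie within the scatter of each other. The value of compound 3 is a limit and not a number, so the step can be read only as a minimum, and its true size stays unknown: the limit of > 25 uM in this assay, at which 1 of the 3 values shown sits.

The compounds shown leave open how the number moves between methyl and cyclopentylmethyl, for example with an ethyl, a longer chain or a smaller ring such as cyclopropylmethyl at this place. They also leave open whether a group of similar reach that carries an amine or a carboxylic acid would give the same result as the cyclopentylmethyl.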